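Replacing thiophen-3-yl with 2H-1,2,3-triazol-2-yl in compound 3

The source may hold more compounds than are shown below. What is called first, only, known or untested is meant among the compounds shown, and "the series" means these compounds.

Three compounds of this urea series have results in a functional assay on a cell-free system (plasma) with sterol O-acyltransferase, Soat (Rattus norvegicus) as the target; on this read-out higher numbers stand for an effect only at larger amounts of compound and lower numbers for an effect already at smaller amounts. Compound 1 `CSc1cc(C)nc(SC)c1NC(=O)N(Cc1ccccc1)Cc1ccc(-c2cnn(C)c2)cc1` sits at a limit of the assay: in this assay compound 1 gives > 0.1 mg/kg. Compound 2 `O=C(Nc1c(F)cc(F)cc1F)N(Cc1ccc(-c2ccsc2)cc1)C1CCCCCC1` likewise sits at a limit: in this assay compound 2 gives > 1 mg/kg. Among the measured compounds shown here, compound 3 `Cc1cc(C)c(NC(=O)N(Cc2ccc(-c3ccsc3)cc2)C2CCCCCC2)c(C)c1` is the only one with a number: in this assay compound 3 gives 0.51 mg/kg. For the measured compounds named here, the single step between compounds differing in one place, an at least 1.9-fold lower number from compound 2 to compound 3 (0.29 log units; that floor lies within the scatter), is 2,4,6-trimethylphenyl in place of 2,4,6-trifluorophenyl on an amide-type nitrogen; its floor rests on the limit of > 1 mg/kg in this assay, at which 1 of the 3 values shown sits, and lies within the scatter.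

Compound 4 `Cc1cc(C)c(NC(=O)N(Cc2ccc(-n3nccn3)cc2)C2CCCCCC2)c(C)c1` differs from compound 3 by 2H-1,2,3-triazol-2-yl in place of thiophen-3-yl on an aromatic carbon. Going by the values given here, no measured step touches this position; the step from compound 2 to compound 3 concerns another part of the molecule and gives no direction for this change. A step of no size beyond the scatter is therefore expected, a 1.2-fold higher number from compound 3 to compound 4 (0.07 log units; within the scatter). Compound 4 is estimated at 0.6 mg/kg, within a range of 0.2 mg/kg to 2 mg/kg; a limit rather than a number remains possible, as seen in the limit of > 0.1 mg/kg in this assay, at which 1 of the 3 values shown sits, and (the limit of > 1 mg/kg in this assay, at which 1 of the 3 values shown sits).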

Compound 4, dose for half-maximal effect: > 1 mg/kg
Compound 4 ended at the assay's limit (the forecaster's own chance of this, stated with the estimate: 40%); middle value at least 1.6-fold (0.22 log units) away from the limit.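

In this assay, the exchange on this aromatic carbon, para to a large group, gives the first step read at this position: an at least 1.9-fold higher number from compound 3 to compound 4 (0.29 log units; that floor lies within the scatter). On these data alone, this shows that 2H-1,2,3-triazol-2-yl does not retain a measured number here, but it does not establish a change beyond the scatter, and the true size of the step remains unknown. The floor of the step rests on a limit of the assay: the limit of > 1 mg/kg in this assay, at which 2 of the 4 values shown sit.

As far as these compounds go, how far the number of compound 4 lies past that limit remains open. Also open, from the compounds shown here alone, is whether a phenyl ring, a pyridin-3-yl ring or a primary amine on this carbon would give a number rather than a limit with the 2,4,6-trimethylphenyl urea and cycloheptyl groups kept in place.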